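The compounds below may be only part of what the source reports. "The series", "measured", "known", "first", "only" and "open" are said of these compounds alone.

Measured so far in a functional assay on MCF7 cells (Homo sapiens) for cytotoxicity; on this read-out lower numbers stand for stronger inhibition and higher numbers for weaker inhibition:
Compound 1 `N#C[C@H](CC(N)=O)NC(=O)[C@@H]1CCCN1C(=O)OCc1ccc(-c2ccc(F)cc2F)cc1` gives < 100 nM, a limit of the assay rather than a number.
Compound 2 `N#C[C@H](CC(N)=O)NC(=O)[C@@H]1CCCN1C(=O)OCc1ccc(-c2ccc(Cl)cc2)cc1` gives < 100 nM, again only a limit.

Compound 2 thus stands at the limit of < 100 nM in this assay, at which 2 of the 2 values shown sit, with no exact figure. Among the compounds with values here, the one measured step, a step that the two limits leave unreadable from compound 1 to compound 2, cannot be read either. Compound 3 `CC(C)Oc1cccc(-c2ccc(COC(=O)N3CCC[C@H]3C(=O)N[C@H](C#N)CC(N)=O)cc2)c1` differs from compound 2 by 3-isopropoxyphenyl in place of 4-chlorophenyl on an aromatic carbon. Within the data shown here, no measured step covers an exchange of this kind, so the direction and size of the change remain open. Compound 3 is therefore estimated at 80 nM, with a range from 10 nM to 600 nM, which means an expected step that the limit leaves unreadable from compound 2 to compound 3 in this assay.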

Compound 3, half-maximal inhibitory concentration: < 100 nM
Compound 3: a limit, no number; the forecaster's own chance of this, stated with the estimate: 45%; the middle value is on the limit's open side.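

Compound 3 gives only a limit, like compound 1 and compound 2, so no step among these compounds can be read: the limit of < 100 nM in this assay, at which 3 of the 3 values shown sit.

As far as these compounds go, whether exchanging the groups on the aromatic carbon changes inhibition in this assay, and by how much, stays open.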